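Notes on the step from compound 3 to compound 4

The source may hold more compounds than are shown below. What is called first, only, known or untested is meant among the compounds shown, and "the series" means these compounds.

Measured so far in an assay for inhibition of inositol hexakisphosphate kinase 3 (Homo sapiens), read by colorimetric assay, coupled enzyme assay and malachite green, with a stated time of 120 min, in the presence of a further agent that is not named here; on this read-out higher numbers stand for weaker inhibition and lower numbers for stronger inhibition:
compound 1 `O=C(O)c1ccc2noc(-c3ccc(Cc4ccccc4)cc3)c2c1` gives 1290 nM
compound 2 `O=C(O)c1ccc2noc(-c3ccc(Oc4ccccc4)cc3)c2c1` gives 550 nM
compound 3 `CC(C)NC(=O)c1ccc(-c2onc3ccc(C(=O)O)cc23)cc1` gives 340 nM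

Compound 3 holds the lowest number of the three. The step of a 1.6-fold lower number from compound 2 to compound 3 (0.21 log units; within the scatter) lies within the scatter, so these two cannot be ordered. The step of a 3.8-fold lower number from compound 1 to compound 3 (0.58 log units; beyond the scatter) lies beyond the scatter, so the isopropylcarbamoyl did better than the benzyl in this assay.

Compound 4 `O=C(O)c1ccc2noc(-c3ccc(N4CCCC4=O)cc3)c2c1` differs from compound 3 by 2-oxopyrrolidin-1-yl in place of isopropylcarbamoyl on an aromatic carbon. Of the measured steps only a 3.8-fold lower number from compound 1 to compound 3 (0.58 log units; beyond the scatter) and a 1.6-fold lower number from compound 2 to compound 3 (0.21 log units; within the scatter) touch the same position, and both exchange a carbon- or oxygen-linked aryl group for the open amide. Among the measured compounds shown here, no measured step exchanges one amide for another, closes a chain into a ring, or removes a hydrogen-bond donor while keeping the acceptor, so the present change has no direct precedent.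

Given that the two amide-bearing compounds sit at the low end, compound 4 is expected to stay near compound 3, with a step of a 1.5-fold higher number from compound 3 to compound 4 (0.17 log units; within the scatter), which is not expected to exceed the scatter. The estimate for compound 4 in this assay is 500 nM, with a range from 200 nM to 1500 nM.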

Compound 4, half-maximal inhibitory concentration: 2170 nM
Compound 4: middle estimate off by 4.3-fold (0.64 log units), on the low side, and the stated range ends below it.
By their numbers in this assay, from the lowest: compounds 3 and 2 (each within the scatter of the next); then compounds 1 and 4 (each within the scatter of the next).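

In this assay, replacing isopropylcarbamoyl with 2-oxopyrrolidin-1-yl (a 6.4-fold higher number from compound 3 to compound 4 (0.80 log units; beyond the scatter)) shows that this aromatic carbon, para to a large group, does not accept any group of this composition equally: both groups have the same heavy-atom count, yet the entering group has a five-membered non-aromatic ring and no hydrogen-bond donor. A carbonyl-bearing group at this position is therefore not enough to keep a compound at the low end of the series, as compound 4 also compares unfavourably with the phenoxy compound (a 3.9-fold higher number from compound 2 to compound 4 (0.60 log units; beyond the scatter)), while the step from the benzyl compound (a 1.7-fold higher number from compound 1 to compound 4 (0.23 log units; within the scatter)) gives no order between those two. No measurement at hand bears on why the two amide-bearing groups behave so differently.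

The compounds shown leave open whether the rise goes with the lost amide hydrogen, the closed ring or the attachment of the group through nitrogen rather than through the carbonyl carbon. An isobutyramido group, linked through nitrogen and keeping its amide hydrogen, and a pyrrolidine-1-carbonyl group, linked through carbon and lacking one, would help to separate these changes.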